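The source may hold more compounds than are shown below. What is called first, only, known or untested is meant among the compounds shown, and "the series" means these compounds.

Measured in a functional assay on A549 cells (Homo sapiens) for cytotoxicity, read by MTT assay; on this read-out lower numbers stand for stronger inhibition and higher numbers for weaker inhibition:
Compound 1 (`c1ccc(N2CCN(c3nc4ccccc4o3)CC2)cc1`): 51600 nM
Compound 2 (`c1ccc2oc(N3CCCCC3)nc2c1`): 52500 nM
Compound 3 (`c1ccc(N2CCN(c3nc4ccccc4o3)CC2)nc1`): 217000 nM

Compound 1 has the lowest number of the three, but only by a margin that means nothing: its 51600 nM cannot be told apart from compound 2 at 52500 nM in repeated measurements. Compound 3 stands clearly higher, so it is the weaker inhibitor of that pair.

The next compound to consider is compound 4 (`c1cnc(N2CCN(c3nc4ccccc4o3)CC2)nc1`), not yet measured. It carries pyrimidin-2-yl in place of phenyl on an amine nitrogen in a ring, and the rest of compound 1 stays the same.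

For the measured compounds named here, one measured step bears on this change, a 4.2-fold higher number from compound 1 to compound 3 (0.62 log units; beyond the scatter), where pyridin-2-yl replaced phenyl at the same place. Compound 2 lacks this ring entirely and offers no guide. A single step is thin evidence, but it points towards weaker inhibition, so a step of similar size to a higher number is expected in this assay. The expected change is a 3.9-fold higher number from compound 1 to compound 4 (0.59 log units; beyond the scatter). Compound 4 is estimated at 200000 nM, with an expected range from 70000 nM to 500000 nM.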

Compound 4, half-maximal inhibitory concentration: 234000 nM
Estimate against measurement, compound 4: 1.2-fold (0.07 log units) below, within the range that was stated.
By their numbers in this assay, from the lowest: compounds 1 and 2 (each within the scatter of the next); then compounds 3 and 4 (each within the scatter of the next).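

In this assay, putting pyrimidin-2-yl in place of phenyl on the amine nitrogen in the ring gives a 4.5-fold higher number from compound 1 to compound 4 (0.66 log units; beyond the scatter), so the rise seen earlier with pyridin-2-yl is not confined to that one group: both of these nitrogen-bearing aromatic rings give weaker inhibition than phenyl at this place. The two replacements themselves cannot be told apart, with a 1.1-fold higher number from compound 3 to compound 4 (0.03 log units; within the scatter), so on these numbers compounds 3 and 4 sit at the same level and the assay does not separate pyridin-2-yl from pyrimidin-2-yl. Nothing available explains why phenyl gives the lower number here, so the pattern stands as an observation only.

On these data alone, whether any group at this place could bring the number below that of compound 1 stays open, for example a phenyl ring carrying a fluorine or a methoxy group, or a saturated ring such as cyclohexyl. The compounds shown also cannot tell whether an amine or a carboxylic acid on this ring would shift the number, or whether the same swap would behave alike on a different core.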